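The source may hold more compounds than are shown below. What is called first, only, known or untested is meant among the compounds shown, and "the series" means these compounds.

Measured so far:
compound 1 `CCOC(=O)C1=Cc2ccccc2OC1(OCc1cn(CC(=O)Nc2ccccc2Br)nn1)C(F)(F)F`: > 150000 nM
compound 2 `CCOC(=O)C1=Cc2ccccc2OC1(OCc1cc(-c2ccc3ccccc3c2)no1)C(F)(F)F`: 65400 nM
compound 3 `CCOC(=O)C1=Cc2ccccc2OC1(OCc1cc(-c2ccc(Cl)cc2)no1)C(F)(F)F`: 18200 nM

In a functional assay on MCF7 cells (Homo sapiens) for inhibition, read by MTT assay, with a stated time of 24 h (a higher number here means a weaker inhibitor, a lower number a stronger inhibitor), compound 1 gives only a limit, > 150000 nM, and stands at the limit of > 150000 nM in this assay, at which 1 of the 3 values shown sits. For the measured compounds named here, compound 2 gives 65400 nM and compound 3 gives 18200 nM; the single measured step, a 3.6-fold lower number from compound 2 to compound 3 (0.56 log units; beyond the scatter), exchanges an aryl group on an aromatic carbon and does not touch the aromatic nitrogen of the five-membered aromatic ring with 3 nitrogen. Compound 4 `CCOC(=O)C1=Cc2ccccc2OC1(OCc1cn(-c2cccc(OC)c2)nn1)C(F)(F)F` differs from compound 1 as follows: 3-methoxyphenyl in place of ((2-bromophenyl)carbamoyl)methyl on an aromatic nitrogen. Going by the values given here, no measured step covers a change at that nitrogen, so the direction is open and the starting point is itself a limit. Compound 4 is expected to give 80000 nM, with a range of 20000 nM to 300000 nM. That estimate means an at least 1.8-fold lower number from compound 1 to compound 4 (0.27 log units; that floor lies within the scatter), an expectation with little support from the measured compounds.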

Compound 4, half-maximal inhibitory concentration: > 150000 nM
Compound 4 ended at the assay's limit (the forecaster's own chance of this, stated with the estimate: 40%); middle value at least 1.8-fold (0.27 log units) from the limit.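

In this assay compound 4 gives > 150000 nM, a limit. Compound 1 gives > 150000 nM, also a limit, so no step between compound 1 and compound 4 can be read: the limit of > 150000 nM in this assay, at which 2 of the 4 values shown sit.

The compounds shown leave open how 3-methoxyphenyl and ((2-bromophenyl)carbamoyl)methyl on the aromatic nitrogen rank against each other.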